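A few compounds are considered here, and "the series" means these few. Any claim that something is new, unique, unknown or untested is made for them only; others in the source may bear on it.

In an assay for inhibition of apolipoprotein B-100 (Homo sapiens), tested at 100 nM (a lower number here means a stronger inhibitor, a higher number a weaker inhibitor), the three measured compounds stand as follows:

compound 1 `Cc1cccc(C(=O)Nc2ccc3c(c2)CC(NS(C)(=O)=O)C3)c1-c1ccc(Cl)cc1` gives 6.6 nM
compound 2 `Cc1cccc(C(=O)Nc2ccc3c(c2)CC(NS(=O)(=O)c2cccs2)C3)c1-c1ccc(Cl)cc1` gives 3 nM
compound 3 `Cc1cccc(C(=O)Nc2ccc3c(c2)CC(CNS(C)(=O)=O)C3)c1-c1ccc(C(F)(F)F)cc1` gives 6.5 nM

Compound 1 and compound 2 differ in one place: thiophen-2-yl in place of methyl on a sulfonyl sulfur. That change made a 2.2-fold lower number from compound 1 to compound 2 (0.34 log units; beyond the scatter). Compound 3 carries a different core; the difference between the two cores is not broken down here. In this assay compound 3 and compound 1 give numbers within the scatter of each other.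

Compound 4 `Cc1cccc(C(=O)Nc2ccc3c(c2)CC(CNS(=O)(=O)c2cccs2)C3)c1-c1ccc(C(F)(F)F)cc1` is compound 3 with the same change, (thiophen-2-yl in place of methyl on a sulfonyl sulfur), at the same place. Because a 2.2-fold lower number from compound 1 to compound 2 (0.34 log units; beyond the scatter) was modest but beyond the scatter, a step of similar size is expected here, a 2.0-fold lower number from compound 3 to compound 4 (0.31 log units; beyond the scatter). On that basis compound 4 is estimated at 3.2 nM, expected to fall between 1.5 nM and 7 nM.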

Compound 4, half-maximal inhibitory concentration: 1.9 nM
Compound 4: the middle estimate sits 1.7-fold (0.23 log units) above what was measured; the measured number falls inside the stated range.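

In this assay, thiophen-2-yl in place of methyl on a sulfonyl sulfur again lowered the number, with a 3.4-fold lower number from compound 3 to compound 4 (0.53 log units; beyond the scatter). The step kept its direction on the second core, and its size cannot be told apart from that of the earlier step: the same change on two cores in this assay, a 2.2-fold lower number (0.34 log units; beyond the scatter) from compound 1 to compound 2 and a 3.4-fold lower number (0.53 log units; beyond the scatter) from compound 3 to compound 4, 1.6-fold (0.19 log units) apart, within the scatter of two such steps. These two pairs do not show that the change would hold on any further core, and they do not show how the two cores themselves compare.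

The compounds shown leave open how other groups on the sulfonyl sulfur, such as phenyl, a longer chain such as butyl, or a dimethylamino group, would read in this assay. They also leave open whether a furan-2-yl would give a step like that of thiophen-2-yl.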